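This account rests on a few compounds, and the source may have more. Where it says the series, first, only, none or still open, it means among the compounds named here.

Compound 1 `CC(=O)Oc1ccccc1C(=O)O[C@H]1CO[C@H]2[C@@H]1OC[C@H]2OC(=O)c1cccc(C)c1` — 0.0203 h
Compound 2 `CC(=O)Oc1ccccc1C(=O)O[C@H]1CO[C@H]2[C@@H]1OC[C@H]2OC(=O)c1ccc([N+](=O)[O-])cc1` — 0.0227 h

In an ADME assay on a cell-free system (plasma, Homo sapiens) for metabolic stability, with Plasma (Rattus norvegicus) as the target, read by HPLC, at pH 7.4 (a lower number here means that the compound disappears faster, a higher number that the compound lasts longer), compound 2 gives 0.0227 h and compound 1 gives 0.0203 h; the two values lie within the scatter of each other, as a 1.1-fold higher number from compound 1 to compound 2 (0.05 log units; within the scatter) shows. Compound 3 `CC(=O)Oc1ccccc1C(=O)O[C@H]1CO[C@H]2[C@@H]1OC[C@H]2OC(=O)c1ccccc1CO[N+](=O)[O-]` differs from compound 2 by 2-((nitrooxy)methyl)phenyl in place of 4-nitrophenyl on a carbonyl carbon. Going by the values given here, the only step measured so far also replaces the group on this carbonyl carbon with another and left the half-life essentially unchanged, so no step beyond the scatter is expected here either. Compound 3 is estimated at 0.022 h, between 0.011 h and 0.044 h, which means an expected step of a 1.0-fold lower number from compound 2 to compound 3 (0.01 log units; within the scatter).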

Compound 3, half-life: 0.0533 h
Compound 3: middle estimate off by 2.4-fold (0.38 log units), on the low side, outside the stated range (above it).
By their numbers in this assay, from the lowest: compounds 1 and 2 (each within the scatter of the next); then compound 3.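

The group on this carbonyl carbon can change the half-life after all: in this assay, 2-((nitrooxy)methyl)phenyl gives a 2.3-fold higher number from compound 2 to compound 3 (0.37 log units; beyond the scatter) and a 2.6-fold higher number from compound 1 to compound 3 (0.42 log units; beyond the scatter). Both steps lie beyond the scatter, whereas the earlier swap between 3-methylphenyl and 4-nitrophenyl did not. Nothing available accounts for this rise.

On these data alone, it remains open whether the nitrooxy part of the new group is what matters. It is also unclear how the half-life would respond to an amine or a carboxylic acid on the phenyl ring, or to a longer chain carrying the nitrooxy group.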